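The source may hold more compounds than are shown below. What is called first, only, known or untested is meant among the compounds shown, and "the series" means these compounds.

Compound 1 `Oc1ccc(-c2cc(-c3cccc(F)c3)cc(-c3cccc(O)c3)n2)cc1`: 3070 nM
Compound 2 `Oc1ccc(-c2cc(-c3cccc(OC(F)(F)F)c3)cc(-c3ccccc3O)n2)cc1`: > 50000 nM
Compound 3 `Oc1cccc(-c2cc(-c3cccc(OC(F)(F)F)c3)cc(-c3cccc(O)c3)n2)c1`: > 50000 nM

All three compounds share one core carrying three aromatic rings and were tested in a functional assay on HCT-15 cells (Homo sapiens) for inhibition; a higher number here means a weaker inhibitor, a lower number a stronger inhibitor. Compound 1 gives a measured number, 3070 nM. For compound 2 the result is a limit of the assay rather than a number, > 50000 nM. For compound 3 the result is likewise only a limit, > 50000 nM. Compound 3 therefore stands at the limit of > 50000 nM in this assay, at which 2 of the 3 values shown sit, and no exact potency is known for it. Compound 4 `Oc1ccc(-c2cc(-c3cccc(OC(F)(F)F)c3)cc(-c3cccc(O)c3)n2)cc1` differs from compound 3 in a single ring: 4-hydroxyphenyl in place of 3-hydroxyphenyl on an aromatic carbon. Going by the values given here, no measured pair shows this same change, so the step of an at least 2.5-fold lower number from compound 3 to compound 4 (0.39 log units; beyond the scatter) is an expectation only, likely small and toward stronger inhibition. Compound 4 is estimated at 20000 nM, within 4000 nM to 100000 nM.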

Compound 4, half-maximal inhibitory concentration: 1730 nM
Compound 4: the middle estimate sits 12-fold (1.06 log units) above what was measured, and the stated range ends above it.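

The position of the hydroxyl on the ring next to the ring nitrogen strongly affects inhibition in this assay: 4-hydroxyphenyl in place of 3-hydroxyphenyl gives an at least 28-fold lower number from compound 3 to compound 4 (1.46 log units; beyond the scatter), and on the other such ring, 3-hydroxyphenyl in place of 2-hydroxyphenyl gives an at least 28-fold lower number from compound 2 to compound 4 (1.46 log units; beyond the scatter). On these data alone, both steps start from a limit of the assay rather than a number, so their full size is unknown: the limit of > 50000 nM in this assay, at which 2 of the 4 values shown sit. Trifluoromethoxy in place of fluoro gives a 1.8-fold lower number from compound 1 to compound 4 (0.25 log units; within the scatter), so that pair cannot be told apart.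

As far as these compounds go, it remains open whether either ring needs a hydroxyl at all, or whether a methoxy or an amine could take its place.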